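Swapping the aryl group: expected cytotoxicity of compound 4

The source may report more compounds than this note shows. Statements on the series, on what has been measured and on what is new or still open speak of the compounds shown alone.

Of the compounds shown here, three sharing one core have been tested in an ADME assay on Huh7.5.1 cells (Homo sapiens) for cytotoxicity, read by ATP content, with a stated time of 48 h; on this read-out lower numbers stand for higher toxicity in this test and higher numbers for lower toxicity in this test. Compound 1 `Cc1oc(-c2ccc(F)cc2)nc1CN1CCC(C(=O)NCCCN2C[C@H](C)C[C@H](C)C2)CC1` gives 12800 nM. Compound 2 `Cc1cccc(F)c1-c1nc(CN2CCC(C(=O)NCCCN3C[C@H](C)C[C@H](C)C3)CC2)c(C)o1` gives 13000 nM. Compound 3 `COc1cccc(Br)c1-c1nc(CN2CCC(C(=O)NCCCN3C[C@H](C)C[C@H](C)C3)CC2)c(C)o1` gives 14900 nM, the highest of the three numbers, though a 1.1-fold higher number from compound 2 to compound 3 (0.06 log units; within the scatter) and a 1.2-fold higher number from compound 1 to compound 3 (0.07 log units; within the scatter) both stay within the scatter, so the three read as one level.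

Compound 4 `Cc1ccc(-c2nc(CN3CCC(C(=O)NCCCN4C[C@H](C)C[C@H](C)C4)CC3)c(C)o2)c(C)c1` has not yet been measured. It differs from compound 3 only in the group attached to the five-membered aromatic ring: 2,4-dimethylphenyl in place of 2-bromo-6-methoxyphenyl on an aromatic carbon

All three measured steps change this same aryl group. a 1.0-fold higher number from compound 1 to compound 2 (0.01 log units; within the scatter) and the two steps onto compound 3 named above all stayed within the scatter, so exchanging one aryl group for another at this position has so far left cytotoxicity in this assay essentially unchanged. The same is therefore expected here: a 1.1-fold lower number from compound 3 to compound 4 (0.04 log units; within the scatter) is estimated to fall within the scatter. Compound 4 is expected to give 13500 nM, with a likely range from 7000 nM to 27000 nM.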

Compound 4, half-maximal cytotoxic concentration: 4110 nM
Compound 4: middle estimate off by 3.3-fold (0.52 log units), on the high side; measured number below the stated range.
By their numbers in this assay, from the lowest: compound 4; then compounds 1, 2 and 3 (each within the scatter of the next).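

Exchanging the aryl group at this position can move the number after all in this assay: there is a 3.6-fold lower number from compound 3 to compound 4 (0.56 log units; beyond the scatter) and a 3.2-fold lower number from compound 2 to compound 4 (0.50 log units; beyond the scatter) and also a 3.1-fold lower number from compound 1 to compound 4 (0.49 log units; beyond the scatter), so a lower number here means higher toxicity in this test for compound 4. Among these four compounds, 2,4-dimethylphenyl stands apart as the only aryl group carrying no halogen, while the fluorine-bearing and bromine-bearing groups sit at one level. Nothing available explains why this group lowers the number.

Open, on these data alone, is whether the lower number goes with the two methyl groups or simply with the absence of a halogen. An unsubstituted phenyl group or a single methyl on the phenyl ring, attached at the same carbon, would help to separate these two readings.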